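The compounds below may be only part of what the source reports. "The series", "measured", "known", "first", "only" and "open" are said of these compounds alone.

Measured in an ADME assay on microsomes from liver (Rattus norvegicus) for metabolic stability, read by LC-MS, with a stated time of 30 min, tested at 0.1 uM; on this read-out lower numbers stand for a less stable compound and higher numbers for a more stable compound:

- compound 1 `COc1cccc(Nc2cc3[nH]c(-c4cccc(C(F)(F)F)c4)nc3cn2)n1`: 49%
- compound 2 `COc1cccnc1Nc1cc2[nH]c(-c3cccc(C(F)(F)F)c3)nc2cn1`: 83%
- compound 3 `COc1ccnc(Nc2cc3[nH]c(-c4cccc(C(F)(F)F)c4)nc3cn2)c1`: 71%

Compound 3 stands second highest of the three. It sits below compound 2, with a number 12 percentage points lower from compound 2 to compound 3 (beyond the scatter), and above compound 1, with a number 22 percentage points higher from compound 1 to compound 3 (beyond the scatter). The next compound, compound 4 `FC(F)(F)c1cccc(-c2nc3cnc(Nc4ccncn4)cc3[nH]2)c1`, carries a different group: pyrimidin-4-yl in place of 4-methoxypyridin-2-yl on a nitrogen on an aromatic ring.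

Among the compounds with values here, none of the measured steps removes the methoxy group or brings in a pyrimidin-4-yl. Each one only exchanges one methoxypyridin-2-yl for another, so they bear on this change indirectly. They do show that small exchanges at this place can matter, the widest being a number 34 percentage points higher from compound 1 to compound 2 (beyond the scatter), and so the expected range stays broad. No step beyond the scatter can be firmly expected in this assay, and the estimate is a number 4 percentage points higher from compound 3 to compound 4 (within the scatter). For compound 4 the estimated value is 75%, with an expected range of 54% to 92%.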

Compound 4, percent of the compound remaining: 88%
Beside the measured number, compound 4's estimate is 13 percentage points below it; the measured number falls inside the stated range.
By their numbers in this assay, from the lowest: compound 1; then compound 3; then compounds 2 and 4 (each within the scatter of the next).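

In this assay, a high number at this position does not depend on a methoxy group: pyrimidin-4-yl, which has none, gives a number 17 percentage points higher from compound 3 to compound 4 (beyond the scatter) and a number 39 percentage points higher from compound 1 to compound 4 (beyond the scatter). Compared with 3-methoxypyridin-2-yl, it gives a number 5 percentage points higher from compound 2 to compound 4 (within the scatter), so a ring with 2 hetero atoms can match the highest methoxypyridin-2-yl result, whereas the earlier compounds compared only methoxypyridin-2-yl groups. No evidence is available to explain this rise.

The compounds shown leave open whether the rise follows the loss of the methoxy group or the second ring nitrogen, and a plain pyridin-2-yl would be needed to separate the two. Going by these compounds, how an amine or a longer alkoxy chain on the pyrimidin-4-yl would read in this assay also remains open.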